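Branched ether chains on a shared aminoquinoline core

This account rests on a few compounds, and the source may have more. Where it says the series, first, only, none or still open, it means among the compounds named here.

Compounds measured so far in an assay on cells with melanin-concentrating hormone receptor 1 (Homo sapiens) as the target, read by radioligand binding; a higher number here means a weaker inhibitor, a lower number a stronger inhibitor:
compound 1, `Nc1ccc2cccc(OCCC(F)(F)F)c2n1`, 722 nM
compound 2, `Nc1ccc2cccc(OCC3CCCO3)c2n1`, a limit of the assay, > 2000 nM
compound 3, `CC(C)C(C)Oc1cccc2ccc(N)nc12`, 199 nM

All three share the same core and differ only in the chain on an oxygen on an aromatic ring. Compound 3 stands lowest of the two actual numbers; its nearest neighbour is compound 1, with a 3.6-fold lower number from compound 1 to compound 3 (0.56 log units; beyond the scatter). The value of compound 2 is only a limit, so for it one knows no more than the limit of > 2000 nM in this assay, at which 1 of the 3 values shown sits. From that limit the change to compound 3 was an at least 10-fold lower number from compound 2 to compound 3 (1.00 log units; beyond the scatter), and from compound 1 to compound 2 the change was an at least 2.7-fold higher number from compound 1 to compound 2 (0.44 log units; beyond the scatter).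

The next compound, compound 4, `CC1CC1COc1cccc2ccc(N)nc12`, keeps the core and the ether oxygen and alters only the chain: (2-methylcyclopropyl)methyl in place of 1,2-dimethylpropyl on an oxygen on an aromatic ring. The two groups match in size and in the absence of donors and acceptors; the steps measured so far all concern a change from a fluorinated or oxygen-bearing chain to a hydrocarbon one, while this step exchanges one hydrocarbon chain for another. Compound 4 is therefore expected to sit near compound 3, with an estimated step of a 1.5-fold higher number from compound 3 to compound 4 (0.18 log units; within the scatter), not beyond the scatter. The estimate for compound 4 in this assay is 300 nM, between 100 nM and 1000 nM.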

Compound 4, half-maximal inhibitory concentration: 1640 nM
Compound 4: middle estimate off by 5.5-fold (0.74 log units), on the low side, and the stated range ends below it.
By their numbers in this assay, from the lowest: compound 3; then compound 1; then compound 4. At a limit, above all of these: compound 2.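

In this assay this place on the ether oxygen proves sensitive to more than the loss of fluorine or of a ring oxygen: with an 8.2-fold higher number from compound 3 to compound 4 (0.92 log units; beyond the scatter) as the result, one hydrocarbon chain of 5 heavy atoms replaces another of 5 heavy atoms, with no hydrogen-bond donors or acceptors on either side. A hydrocarbon chain as such therefore does not secure the lower number, as compound 3 alone might have suggested, and compound 4 goes against that reading, with a 2.3-fold higher number from compound 1 to compound 4 (0.36 log units; beyond the scatter) placing the ring-bearing chain above the 3,3,3-trifluoropropyl chain as well. The step of an at least 1.2-fold lower number from compound 2 to compound 4 (0.08 log units; that floor lies within the scatter) is only a floor and sets no order between those two chains, since the value it starts from is a limit: the limit of > 2000 nM in this assay, at which 1 of the 4 values shown sits.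

The compounds shown do not separate the three-membered ring from the different branching of the two chains, and a plain cyclopropylmethyl chain or an unbranched pentyl chain on the same oxygen would bear on that. Also open, from the compounds shown here alone, is how a chain ending in an amine or a carboxylic acid would fare at this place.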